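Another aryl group on the benzyl arm of compound 3

This account rests on a few compounds, and the source may have more. Where it says the series, first, only, none or still open, it means among the compounds named here.

Measured in an assay on CHO cells for displacement of a labelled ligand from Alpha-1A adrenergic receptor (Homo sapiens); on this read-out higher numbers stand for weaker inhibition and lower numbers for stronger inhibition:
compound 1 `COc1cccc(OC)c1OCCNCCOc1ccccc1OCc1ccc(Cl)cc1`: 0.251 nM
compound 2 `COc1cccc(OC)c1OCCNCCOc1ccccc1OCc1cccc(C)c1`: 0.398 nM
compound 3 `COc1cccc(OC)c1OCCNCCOc1ccccc1OCc1cccc([N+](=O)[O-])c1`: 0.316 nM

Compound 3 holds the second highest of the three numbers, yet a 1.3-fold higher number from compound 1 to compound 3 (0.10 log units; within the scatter) and a 1.3-fold lower number from compound 2 to compound 3 (0.10 log units; within the scatter) both stay within the scatter, so the three compounds are not separated. Compound 4 `COc1ccc(COc2ccccc2OCCNCCOc2c(OC)cccc2OC)cc1` differs from compound 3 in one place: 4-methoxyphenyl in place of 3-nitrophenyl on a saturated chain carbon bound to an oxygen on an aromatic ring. Within the data shown here, the steps that bear on this exchange are the earlier swaps of the same group, a 1.6-fold higher number from compound 1 to compound 2 (0.20 log units; within the scatter) and the two just named, none of them beyond the scatter. Compound 4 is therefore expected to give no step beyond the scatter in this assay, estimated as a 1.0-fold higher number from compound 3 to compound 4 (0.01 log units; within the scatter). The estimate for compound 4 is 0.32 nM, with a range from 0.13 nM to 0.8 nM.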

Compound 4, inhibition constant: 2 nM
Compound 4: middle estimate off by 6.3-fold (0.80 log units), on the low side; measured number above the stated range.
By their numbers in this assay, from the lowest: compounds 1, 3 and 2 (each within the scatter of the next); then compound 4.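

Among these compounds, with 4-methoxyphenyl on the saturated chain carbon bound to an oxygen on an aromatic ring, this assay shows the first steps beyond the scatter at this position: a 6.3-fold higher number from compound 3 to compound 4 (0.80 log units; beyond the scatter) and a 5.0-fold higher number from compound 2 to compound 4 (0.70 log units; beyond the scatter). The exchange of methoxy for chloro on an aromatic carbon gives the largest of these steps, an 8.0-fold higher number from compound 1 to compound 4 (0.90 log units; beyond the scatter), so this position does not accept every aryl group equally. No measured evidence accounts for the change. Going by these compounds, it remains open whether 3-methoxyphenyl in the same place would stay close to compound 3 or follow compound 4, which would show whether the methoxy group or its ring position sets the number.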